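Series notes: acetyl in place of methyl on an oxygen

The compounds below may be only part of what the source reports. "The series", "measured", "known", "first", "only" and "open" are said of these compounds alone.

Measured in a toxicity assay on the whole organism (strain CD-1) for cytotoxicity, with Mus musculus as the target, with a stated time of 14 days, at a dose of 150 mg/kg by the intraperitoneal route; on this read-out lower numbers stand for a stronger effect and higher numbers for a weaker effect at the one dose given:
compound 1 `COc1c(C(=O)O)cc(F)c(F)c1F` gives 80%
compound 2 `O=C(O)c1c(O)c(F)cc(F)c1F` gives 66%
compound 3 `COC(=O)c1cc(F)c(F)c(F)c1O` gives 100%

Among these three numbers compound 1 stands second highest. Its nearest neighbour is compound 2, whose number lies lower by a gap beyond the usual scatter; compound 3 lies furthest, higher by a gap also beyond the scatter. No two of these compounds differ in only one place, so no single step between measured compounds can be read off.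

Compound 4 `CC(=O)Oc1c(C(=O)O)cc(F)c(F)c1F` is not yet measured. It differs from compound 1 by acetyl in place of methyl on an oxygen on an aromatic ring. Going by the values given here, the measured set offers no step of this kind to go by; the expectation in this assay is a shift of no more than the scatter, in no preferred direction. The estimate for compound 4 is 78% with a range of 55% to 100%. This estimate corresponds to an expected step of a number 2 percentage points lower from compound 1 to compound 4 (within the scatter).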

Compound 4, a percentage reported as activity, at one dose (the size of the read-out at that dose, not a potency): 70%
Compound 4: the middle estimate sits 8 percentage points above what was measured, and the stated range covers the measured number.
By their numbers in this assay, from the lowest: compounds 2, 4 and 1 (each within the scatter of the next, the first and the last beyond it); then compound 3.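

In this assay, acetyl in place of methyl on an oxygen on an aromatic ring gives a number 10 percentage points lower from compound 1 to compound 4 (within the scatter). Going by these compounds alone, this is the first single-place step, and it shows that this oxygen carries acetyl as well as methyl without a difference that can be told from the scatter. No measured evidence bears on the reason for this result.

From the compounds shown here alone, whether an amine or a longer acyl chain at this position would also stay within the scatter of compound 1 remains open. So does whether the same step would hold at any other dose.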